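Amine substituent changes and buffer solubility, compounds 1 to 4

The compounds below may be only part of what the source reports. "The series", "measured", "known", "first", "only" and "open" are said of these compounds alone.

Measured so far:
compound 1 `CCn1c(NC2CC2)nc2ccsc2c1=O`: 430 ug/mL
compound 2 `CCn1c(NC(C)(C)C)nc2ccsc2c1=O`: 3.7 ug/mL
compound 3 `CCn1c(NC2CCOCC2)nc2ccsc2c1=O`: 37 ug/mL

In a physicochemical assay for solubility, in phosphate buffer, at pH 6.8 (on this read-out lower numbers stand for lower solubility and higher numbers for higher solubility), compound 1 gives 430 ug/mL, compound 2 gives 3.7 ug/mL and compound 3 gives 37 ug/mL. Compound 3 stands second highest of the three numbers, separated from both neighbours by more than the scatter: a 12-fold lower number from compound 1 to compound 3 (1.07 log units; beyond the scatter), and a 10-fold higher number from compound 2 to compound 3 (1.00 log units; beyond the scatter).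

Compound 4 `CCCNc1nc2ccsc2c(=O)n1CC` is not yet measured in this assay. Its change from compound 3 is propyl in place of oxan-4-yl on a nitrogen on an aromatic ring.

All three measured steps alter the same group on the same nitrogen, so all bear on this one. Both replacements of cyclopropyl lowered the number, the acyclic branched group most: a 120-fold lower number from compound 1 to compound 2 (2.07 log units; beyond the scatter) and a 12-fold lower number from compound 1 to compound 3 (1.07 log units; beyond the scatter). Between the two non-cyclopropyl groups the acyclic one sits at the lower end: a 10-fold higher number from compound 2 to compound 3 (1.00 log units; beyond the scatter). Propyl is acyclic like tert-butyl but smaller, so a step down from compound 3 of modest size is expected, smaller than the gap to compound 2; the expected step is a 2.5-fold lower number from compound 3 to compound 4 (0.39 log units; beyond the scatter). Compound 4 is therefore estimated at 15 ug/mL, with a range from 4 ug/mL to 60 ug/mL.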

Compound 4, solubility: 69 ug/mL
The estimate for compound 4 lay 4.6-fold (0.66 log units) below the measured number, and the stated range ends below it.
By their numbers in this assay, from the lowest: compound 2; then compounds 3 and 4 (each within the scatter of the next); then compound 1.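

In this assay, propyl in place of oxan-4-yl on a nitrogen on an aromatic ring gives a 1.9-fold higher number from compound 3 to compound 4 (0.27 log units; within the scatter) and so does not separate the open chain from the six-membered non-aromatic ring with its hetero atom, which shows that the absence of a ring does not by itself put a compound at the low end of this small set. The two acyclic groups lie far apart, with propyl in place of tert-butyl giving a 19-fold higher number from compound 2 to compound 4 (1.27 log units; beyond the scatter) and thus showing that the low end belongs to compound 2 alone rather than to acyclic groups in general, while propyl in place of cyclopropyl gives a 6.2-fold lower number from compound 1 to compound 4 (0.79 log units; beyond the scatter) and leaves compound 1 clear of all three others. No measurement offered here accounts for these differences.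

From the compounds shown here alone, whether the high number of compound 1 belongs to cyclopropyl alone remains open, and cyclobutyl, isopropyl or ethyl on the same nitrogen would bear on that. A longer chain such as butyl, or a ring carrying an amine such as piperidin-4-yl, would also show how far the order of these groups extends.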